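The source may hold more compounds than are shown below. What is called first, only, known or untested is meant among the compounds shown, and "the series" means these compounds.

Working notes on the series

Three analogues of the shared core have been measured. Compound 1 `CC(C)[C@H](NC(=O)CCN(C)C)c1cccc(F)c1N1CCN(C(=O)[C@@H]2CN(C(C)C)C[C@H]2c2ccc(C(F)(F)F)c(F)c2)CC1` gives 51 nM in an assay on HEK293 cells for displacement of a labelled ligand from Melanocortin receptor 4 (Homo sapiens); a higher number here means a weaker inhibitor, a lower number a stronger inhibitor. Compound 2 `CC(C)[C@H](NC(=O)CCN(C)C)c1cccc(F)c1N1CCN(C(=O)[C@@H]2CN(C(C)C)C[C@H]2c2cccc(F)c2)CC1` gives 560 nM, and compound 3 `CC(C)[C@H](NC(=O)CCN(C)C)c1cccc(F)c1N1CCN(C(=O)[C@@H]2CN(C(C)C)C[C@H]2c2cccc(Cl)c2)CC1` gives 370 nM. Compound 3 therefore stands second highest of the three numbers: its nearest neighbour is compound 2, with a 1.5-fold lower number from compound 2 to compound 3 (0.18 log units; within the scatter), a gap inside the scatter, while compound 1 sits furthest away, with a 7.3-fold higher number from compound 1 to compound 3 (0.86 log units; beyond the scatter).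

The next compound, compound 4 `CC(C)[C@H](NC(=O)CCN(C)C)c1cccc(F)c1N1CCN(C(=O)[C@@H]2CN(C(C)C)C[C@H]2c2ccc(C(F)(F)F)cc2F)CC1`, carries the change (2-fluoro-4-(trifluoromethyl)phenyl in place of 3-chlorophenyl on a saturated ring carbon). Among the compounds with values here, two measured steps bear on it. Going from the trifluoromethyl-bearing aryl of compound 1 to the plain fluorophenyl of compound 2 gave an 11-fold higher number from compound 1 to compound 2 (1.04 log units; beyond the scatter), and the step of a 7.3-fold higher number from compound 1 to compound 3 (0.86 log units; beyond the scatter) shows that the chlorophenyl of compound 3 also lags well behind compound 1. Compound 4 brings back a fluorine and a trifluoromethyl on the same aryl as in compound 1, though the fluorine now sits as part of a 2-fluoro-4-(trifluoromethyl)phenyl group, so the swap back is not an exact reversal and the fluorine shift carries some uncertainty. A sizeable drop in the number toward compound 1 is expected, estimated as a 4.1-fold lower number from compound 3 to compound 4 (0.61 log units; beyond the scatter). Compound 4 is accordingly estimated at 90 nM in this assay, with a range of 35 nM to 250 nM.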

Compound 4, inhibition constant: 61 nM
Estimate against measurement, compound 4: 1.5-fold (0.17 log units) above, and the stated range covers the measured number.
By their numbers in this assay, from the lowest: compounds 1 and 4 (each within the scatter of the next); then compounds 3 and 2 (each within the scatter of the next).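

In this assay the result widens what the saturated ring carbon accepts: the 2-fluoro-4-(trifluoromethyl)phenyl group also gives a clear gain over the aryl groups without trifluoromethyl, with a 6.1-fold lower number from compound 3 to compound 4 (0.78 log units; beyond the scatter) against the 3-chlorophenyl group and a 9.2-fold lower number from compound 2 to compound 4 (0.96 log units; beyond the scatter) against the 3-fluorophenyl group. The two aryl groups carrying trifluoromethyl cannot be told apart, with a 1.2-fold higher number from compound 1 to compound 4 (0.08 log units; within the scatter) for the exchange of the 3-fluoro-4-(trifluoromethyl)phenyl group for the 2-fluoro-4-(trifluoromethyl)phenyl group, so among the four compounds the link between trifluoromethyl and the lower numbers no longer rests on compound 1 alone, and no compound shown goes against it. No measurement is available that explains this link or the match between the two fluorine placements.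

Because every aryl group here carrying trifluoromethyl also carries fluorine, the compounds shown do not separate the contribution of the two groups, and an aryl group with trifluoromethyl and no fluorine would be needed to do so. Also open, on these data alone, is whether a nitrile, a methoxy group or an amine in place of the trifluoromethyl on this aryl ring would keep the number as low as in compound 1 and compound 4.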